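An Amide in Place of a Ketone: What to Expect

This account rests on a few compounds, and the source may have more. Where it says the series, first, only, none or still open, it means among the compounds named here.

compound 1 `COc1cc(-c2nnc(SCC(=O)c3ccc(C)cc3)n2N)cc(OC)c1OC`: > 100000 nM
compound 2 `COc1ccc(C(=O)CSc2nnc(-c3cc(OC)c(OC)c(OC)c3)n2N)cc1`: > 100000 nM

Two measured compounds share one core and differ only in the substituent on the aryl ketone. In a functional assay on HepG2 cells (Homo sapiens) for antiproliferative activity, read by MTT assay, with a stated time of 48 h (on this read-out higher numbers stand for weaker inhibition and lower numbers for stronger inhibition), compound 1 reaches only a limit of the assay, > 100000 nM. Compound 2 likewise stops at a limit, > 100000 nM. The step from compound 1 to compound 2, a step that the two limits leave unreadable from compound 1 to compound 2, cannot be read because the limit of > 100000 nM in this assay, at which 2 of the 2 values shown sit, holds both values, so compound 2 stands at the limit itself, with no number behind it.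

Compound 3 `COc1cc(-c2nnc(SCC(=O)Nc3ccccc3F)n2N)cc(OC)c1OC` differs from compound 2 by (2-fluorophenyl)amino in place of 4-methoxyphenyl on a carbonyl carbon. Going by the values given here, no measured step bears on this kind of change; the one step available is unreadable. With nothing to point either way, compound 3 is expected to remain around 100000 nM, within 30000 nM to 300000 nM, most likely again as a limit. The expected step of a number no higher from compound 2 to compound 3 (the limit leaves the size open) is therefore none beyond the scatter.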

Compound 3, half-maximal inhibitory concentration: 18700 nM
Compound 3: middle estimate off by 5.3-fold (0.73 log units), on the high side; measured number below the stated range.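

With (2-fluorophenyl)amino on the carbonyl carbon, the series gives its first true number in this assay: compound 3 gives 18700 nM. This shows that the group on this carbonyl carbon can change the read-out, which the earlier pair could not show, with an at least 5.3-fold lower number from compound 2 to compound 3 (0.72 log units; beyond the scatter) and an at least 5.3-fold lower number from compound 1 to compound 3 (0.72 log units; beyond the scatter). Both steps give only a minimum size, because compound 1 and compound 2 stop at a limit of the assay: the limit of > 100000 nM in this assay, at which 2 of the 3 values shown sit.

The change brings in the amide hydrogen and the 2-fluorophenyl ring together, so the compounds shown do not tell which of the two carries the step. A plain phenylamino group or a (4-methoxyphenyl)amino group on the same carbonyl carbon would be needed to separate them.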